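The source may report more compounds than this note shows. Statements on the series, on what has been measured and on what is new or still open speak of the compounds shown alone.

Measured so far in a functional assay on MGC-803 cells (Homo sapiens) for inhibition, read by MTT assay, with a stated time of 48 h; on this read-out higher numbers stand for weaker inhibition and lower numbers for stronger inhibition:
- compound 1 `C/C=C/C(=O)N(Cc1cccc(O)c1)c1cc(OC)c(OC)c(OC)c1`: 14100 nM
- compound 2 `C/C=C/C(=O)N(Cc1ccc(OC)c(O)c1)c1cc(OC)c(OC)c(OC)c1`: 27 nM

Not yet measured:
- compound 3 `C/C=C/C(=O)N(Cc1ccc(OC)cc1)c1cc(OC)c(OC)c(OC)c1`

Of the two measured compounds, compound 2 holds the lower number at 27 nM. Compound 3 differs from it by hydrogen in place of hydroxy on an aromatic carbon, which is hydrogen in place of hydroxy on an aromatic carbon, turning 3-hydroxy-4-methoxyphenyl into 4-methoxyphenyl.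

Within the data shown here, no measured step covers this exchange directly. Among the measured compounds shown here, the one step that bears on it is a 520-fold lower number from compound 1 to compound 2 (2.72 log units; beyond the scatter), a large change that came from methoxy in place of hydrogen on an aromatic carbon. It shows that a single exchange on this ring can move the number in this assay a long way. Compound 3 keeps that methoxy group, so a return to the level of compound 1 at 14100 nM is not expected. The effect of losing the hydroxy alone is unmeasured, which leaves the range wide.

The expected change is a 15-fold higher number from compound 2 to compound 3 (1.17 log units; beyond the scatter), a move to a higher number but well short of the measured step. For compound 3 the estimated value is 400 nM, with an expected range of 80 nM to 3000 nM.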

Compound 3, half-maximal inhibitory concentration: 450 nM
Compound 3: the middle estimate sits 1.1-fold (0.05 log units) below what was measured, and the stated range covers the measured number.
By their numbers in this assay, from the lowest: compound 2; then compound 3; then compound 1.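

In this assay, the step to the 4-methoxyphenyl group, a 17-fold higher number from compound 2 to compound 3 (1.22 log units; beyond the scatter), shows that the hydroxy ortho to a methoxy group counts on its own, which the earlier pair could not show since only the methoxy changed there. The methoxy step, a 520-fold lower number from compound 1 to compound 2 (2.72 log units; beyond the scatter), is still the larger of the two, so in this small set losing the methoxy costs more than losing the hydroxy, and compound 2, which carries both groups, holds the lowest number. The step of a 31-fold lower number from compound 1 to compound 3 (1.50 log units; beyond the scatter) adds that a ring with the methoxy and no hydroxy still lies well ahead of a ring with the hydroxy and no methoxy, though neither reaches the level of compound 2, and nothing available here gives a reason for these differences.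

As far as these compounds go, whether an amine or a fluorine in place of the hydroxy would keep the number near that of compound 2 remains open. Equally open, from the compounds shown here alone, is whether an ethoxy group or a longer chain could stand in for the methoxy without the loss seen on removing it.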